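The compounds below may be only part of what the source reports. "The series", "measured", "known", "first", "only" and "open" are said of these compounds alone.

Measured in a functional assay on MCF7 cells (Homo sapiens) for antiproliferative activity, read by MTT assay, with a stated time of 48 h; a higher number here means a weaker inhibitor, a lower number a stronger inhibitor:
- compound 1 `CCOc1ccc(NC(=O)c2ccc(C(CC)(CC)c3ccc(OCCC(O)(CC)CC)c(C)c3)n2CC)cc1`: > 50000 nM, a limit
- compound 2 `CCC(C)C(NC(=O)c1ccc(C(CC)(CC)c2ccc(OCCC(O)(CC)CC)c(C)c2)n1CC)C(=O)OC`: > 50000 nM, a limit
- compound 3 `CCOC(=O)CN(C)C(=O)c1ccc(C(CC)(CC)c2ccc(OCCC(O)(CC)CC)c(C)c2)n1CC`: 3210 nM

Compound 3 is the only one of the three with a number. Compound 1 and compound 2 both stand at the limit of > 50000 nM in this assay, at which 2 of the 3 values shown sit.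

Compound 4 `CCn1c(C(=O)N(C)CCO)ccc1C(CC)(CC)c1ccc(OCCC(O)(CC)CC)c(C)c1` differs from compound 3 by hydroxymethyl in place of ethoxycarbonyl on a saturated chain carbon bound to an amide-type nitrogen: (ethoxycarbonyl)methyl gives way to 2-hydroxyethyl. Within the data shown here, two measured steps bear on this, an at least 15-fold lower number from compound 1 to compound 3 (1.19 log units; beyond the scatter) and an at least 15-fold lower number from compound 2 to compound 3 (1.19 log units; beyond the scatter). Both are large, but each changes more of the group on the carbonyl carbon, so neither isolates this change. A moderate loss of activity is therefore expected, not a step of that size. In this assay the expected step is a 2.5-fold higher number from compound 3 to compound 4 (0.40 log units; beyond the scatter), toward a higher number. Compound 4 is estimated at 8000 nM, with an expected range of 2000 nM to 40000 nM.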

Compound 4, half-maximal inhibitory concentration: 2870 nM
For compound 4 the middle estimate is 2.8-fold (0.45 log units) above the measured one; the measured number falls inside the stated range.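

In this assay, hydroxymethyl in place of ethoxycarbonyl on a saturated chain carbon bound to an amide-type nitrogen gives a 1.1-fold lower number from compound 3 to compound 4 (0.05 log units; within the scatter), so ethoxycarbonyl is not needed at this place for the activity of compound 3. The (2-hydroxyethyl)(methyl)amino group also gives large steps, an at least 17-fold lower number from compound 2 to compound 4 (1.24 log units; beyond the scatter) and an at least 17-fold lower number from compound 1 to compound 4 (1.24 log units; beyond the scatter). Both steps start from a limit of the assay: the limit of > 50000 nM in this assay, at which 2 of the 4 values shown sit.

From the compounds shown here alone, whether an amine, a carboxylic acid or a longer chain at this place would give a similar number stays open. So does whether the methyl on the amide nitrogen or the chain carries those large steps.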